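Exchanging 4-cyanophenyl for 3,4-dichlorophenyl on a shared core

This account rests on a few compounds, and the source may have more. Where it says the series, first, only, none or still open, it means among the compounds named here.

In an ADME assay on L6 cells (Rattus norvegicus) for cytotoxicity, read by resazurin assay, with a stated time of 70 h (on this read-out higher numbers stand for weaker inhibition and lower numbers for stronger inhibition), compound 3 `CC(=O)Oc1ccc2c(c1)C(C)=CC(C)(C)N2Cc1ccc(C#N)cc1` gives 29000 nM, the higher of the two exact numbers available. Compound 2 `CC1=CC(C)(C)N(Cc2ccc(C)cc2)c2ccc(O)cc21` gives 8100 nM, a gap beyond the usual scatter. Compound 1 `CC1=CC(C)(C)N(Cc2cccc(C(F)(F)F)c2)c2ccc(OCc3cccc(C(F)(F)F)c3)cc21` is reported only as a limit, > 180000 nM.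

Compound 4 `CC(=O)Oc1ccc2c(c1)C(C)=CC(C)(C)N2Cc1ccc(Cl)c(Cl)c1` carries 3,4-dichlorophenyl in place of 4-cyanophenyl on a saturated chain carbon bound to a nitrogen on an aromatic ring in a ring. Going by the values given here, no measured pair shows this exchange, so only a modest shift towards a lower number is expected in this assay, and it may not clear the scatter. The expected change is a 1.6-fold lower number from compound 3 to compound 4 (0.21 log units; within the scatter). For compound 4, the estimated value is 18000 nM, with an expected range of 5000 nM to 60000 nM.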

Compound 4, half-maximal inhibitory concentration: 28000 nM
Compound 4: middle estimate off by 1.6-fold (0.19 log units), on the low side; low and high end bracket the measured number.
By their numbers in this assay, from the lowest: compound 2; then compounds 4 and 3 (each within the scatter of the next). At a limit, above all of these: compound 1.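

In this assay, going by these compounds alone, placing 3,4-dichlorophenyl in place of 4-cyanophenyl on a saturated chain carbon bound to a nitrogen on an aromatic ring in a ring gives a 1.0-fold lower number from compound 3 to compound 4 (0.02 log units; within the scatter), the first reading of a single change at this place. On this read-out, the two groups cannot be told apart on the shared core. No measurement shown bears on why the exchange leaves the number within the scatter.

From the compounds shown here alone, whether an amine or a carboxylic acid in place of 3,4-dichlorophenyl would move the number beyond the scatter remains open.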